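The compounds below may be only part of what the source reports. "The series", "measured", "known", "first", "only" and "open" are said of these compounds alone.

Working notes on the series. In a functional assay on A549 cells (Homo sapiens) for antiproliferative activity, read by MTT assay, with a stated time of 48 h (a higher number here means a weaker inhibitor, a lower number a stronger inhibitor), compound 1 `CC(=O)OC/C1=C/C[C@](C)(CCC=C(C)C)/C=C/[C@@H](OC(=O)C=C(C)C)[C@](C)(O)/C=C/C1=O` gives 2950 nM and compound 3 `C=C1/C=C/C(=O)/C(CO)=C\C[C@](C)(CCC=C(C)C)/C=C/[C@H]1OC(=O)C=C(C)C` gives 3090 nM, the two lying within the scatter of each other, while compound 2 `CC(=O)OC/C1=C/C[C@](C)(CCC=C(C)C)/C=C/[C@@H](OC(=O)C=C(C)C)[C@](C)(OC(C)=O)/C=C/C1=O` gives 15100 nM. Compound 4 `CC(C)=CCC[C@]1(C)/C=C/[C@@H](OC(=O)C=C(C)C)[C@](C)(O)/C=C/C(=O)/C(CN(C)C)=C\C1` departs from compound 1 as follows: dimethylamino in place of acetoxy on a saturated chain carbon bound to a double-bonded ring carbon. In words, dimethylamino stands in place of acetoxy on a saturated chain carbon bound to a double-bonded ring carbon. Among the compounds with values here, the only measured single-place step, a 5.1-fold higher number from compound 1 to compound 2 (0.71 log units; beyond the scatter), is modest and is a different change, acetyl in place of hydrogen on an oxygen on a saturated carbon. It gives weak guidance, so no step beyond the scatter is expected in this assay. The expected step is a 1.2-fold higher number from compound 1 to compound 4 (0.07 log units; within the scatter). For compound 4 the estimate is 3500 nM, with an expected range of 1000 nM to 12000 nM.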

Compound 4, half-maximal inhibitory concentration: 590 nM
Estimate against measurement, compound 4: 5.9-fold (0.77 log units) above; measured number outside the range, below it.
By their numbers in this assay, from the lowest: compound 4; then compounds 1 and 3 (each within the scatter of the next); then compound 2.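

In this assay, the acetoxy group is not needed at this place, a saturated chain carbon bound to a double-bonded ring carbon: with dimethylamino there, the series shows a 5.0-fold lower number from compound 1 to compound 4 (0.70 log units; beyond the scatter). This is the first change shown at this place, and it runs opposite in direction to the step at the other place, a 5.1-fold higher number from compound 1 to compound 2 (0.71 log units; beyond the scatter). No measurement shown gives a reason for the gain. On these data alone, whether it is particular to dimethylamino remains open; diethylamino, a primary amine or a carboxylic acid at this place would test that.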